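A few compounds are considered here, and "the series" means these few. Any claim that something is new, unique, unknown or untested is made for them only; others in the source may bear on it.

Compound 1 `CC1=C(C(=O)OCC(C)C)C(c2ccco2)NC(=S)N1` gives 7%.
Compound 2 `CC1=C(C(=O)OC(C)(C)C)C(c2ccco2)NC(=S)N1` gives 3%.
Compound 3 `CC1=C(C(=O)OCC(C)C)C(c2ccsc2)NC(=S)N1` gives 8%.

All three were tested in an assay on membranes from CHO cells for displacement of a labelled ligand from adenosine receptor A1 (Homo sapiens), read by scintillation counting, with a stated time of 60 min, tested at 1 uM; on this read-out higher numbers stand for more inhibition at the one concentration tested (going by the name of the read-out) and lower numbers for less inhibition. Compound 1 and compound 3 share one core and differ only in the difference (thiophen-3-yl in place of furan-2-yl on a saturated ring carbon); the step between them, a number 1 percentage points higher from compound 1 to compound 3 (within the scatter), is within the scatter, so their two numbers cannot be told apart. Compound 2 arises from compound 1 by the change (tert-butyl in place of isobutyl on an oxygen next to a carbonyl group), and the step of a number 4 percentage points lower from compound 1 to compound 2 (within the scatter) is also within the scatter. All three numbers are small, and none of the three compounds can be called weaker or stronger than another on this read-out.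

Compound 4 `CC1=C(C(=O)OC(C)(C)C)C(c2ccsc2)NC(=S)N1` has not yet been measured. It arises from compound 3 by the same change, (tert-butyl in place of isobutyl on an oxygen next to a carbonyl group), that turns compound 1 into compound 2. Going by the values given here, since that change made only the step of a number 4 percentage points lower from compound 1 to compound 2 (within the scatter), the step from compound 3 to compound 4 is expected to be about as small, a number 3 percentage points lower from compound 3 to compound 4 (within the scatter). Compound 4 is therefore estimated at 5% in this assay, expected to fall between -5% and 15%.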

Compound 4, a percentage reported as inhibition, at one concentration (the size of the read-out at that concentration, not a potency): 16%
For compound 4 the middle estimate is 11 percentage points below the measured one, and the stated range ends below it.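

Carrying the change to tert-butyl from one core to the other shows no measurable difference between the two cores: the same change on two cores in this assay, a number 4 percentage points lower (within the scatter) from compound 1 to compound 2 and a number 8 percentage points higher (within the scatter) from compound 3 to compound 4, 12 percentage points apart, within the scatter of two such steps. Going by these compounds alone, the step of a number 13 percentage points higher from compound 2 to compound 4 (beyond the scatter) is the only new step that clears the scatter, yet it cannot be told apart from the earlier step for the same thiophen-3-yl swap: the same change on two cores in this assay, a number 1 percentage points higher (within the scatter) from compound 1 to compound 3 and a number 13 percentage points higher (beyond the scatter) from compound 2 to compound 4, 12 percentage points apart, within the scatter of two such steps. With the other new step, a number 8 percentage points higher from compound 3 to compound 4 (within the scatter), also inside the scatter, these four compounds do not show that either change carries over with the same size, nor that its size depends on the core.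

Still open, from the compounds shown here alone, is how these cores would read with a longer chain on the ester oxygen, or with a carboxylic acid or an amide in place of the ester. Also open, going by these compounds, is whether a phenyl ring in place of furan-2-yl or thiophen-3-yl would give numbers clearly apart from these.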